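This account rests on a few compounds, and the source may have more. Where it says the series, first, only, none or still open, it means among the compounds named here.

Of the compounds shown here, three built on one shared core have been tested in a functional assay on HeLa cells (Homo sapiens) for cytotoxicity, read by sulforhodamine B assay; on this read-out lower numbers stand for stronger inhibition and higher numbers for weaker inhibition. Compound 1 `CC(C)C(NS(=O)(=O)c1cccc(Br)c1)C1=CC(=O)c2c(O)ccc(O)c2C1=O` gives 860 nM in this assay. Compound 2 `CC(C)C(NS(=O)(=O)c1ccccc1Br)C1=CC(=O)c2c(O)ccc(O)c2C1=O` differs from compound 1 by 2-bromophenyl in place of 3-bromophenyl on a sulfonyl sulfur, and in this assay compound 2 gives 8310 nM, so that a 9.7-fold higher number from compound 1 to compound 2 (0.99 log units; beyond the scatter). Compound 3 `CC(NS(=O)(=O)c1cccc(Br)c1)C1=CC(=O)c2c(O)ccc(O)c2C1=O` differs from compound 1 by methyl in place of isopropyl on a saturated chain carbon bound to a double-bonded ring carbon and a sulfonamide nitrogen; in this assay compound 3 gives 6350 nM, which means a 7.4-fold higher number from compound 1 to compound 3 (0.87 log units; beyond the scatter). The values of compound 2 and compound 3 lie within the usual scatter of each other, so nothing separates them.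

Compound 4 `CC(NS(=O)(=O)c1ccccc1Br)C1=CC(=O)c2c(O)ccc(O)c2C1=O` has not yet been measured. It differs from compound 3 by 2-bromophenyl in place of 3-bromophenyl on a sulfonyl sulfur, which is the same change already seen between compound 1 and compound 2, made here on the core of compound 3 rather than on the core of compound 1. A step of similar size is expected, a 6.3-fold higher number from compound 3 to compound 4 (0.80 log units; beyond the scatter), because the same change gave a 9.7-fold higher number from compound 1 to compound 2 (0.99 log units; beyond the scatter). This rests on a single earlier pair, so the expectation is held loosely. Compound 4 is therefore expected to give 40000 nM in this assay, with a likely range from 12000 nM to 130000 nM.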

Compound 4, half-maximal inhibitory concentration: 6200 nM
Compound 4: middle estimate off by 6.5-fold (0.81 log units), on the high side; measured number outside the range, below it.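

On the core of compound 3, 2-bromophenyl in place of 3-bromophenyl gives a 1.0-fold lower number from compound 3 to compound 4 (0.01 log units; within the scatter) in this assay, so the large step seen on the core of compound 1 does not carry over, and the two steps differ: the same change on two cores in this assay, a 9.7-fold higher number (0.99 log units; beyond the scatter) from compound 1 to compound 2 and a 1.0-fold lower number (0.01 log units; within the scatter) from compound 3 to compound 4, 9.9-fold (1.00 log units) apart, beyond the scatter of two such steps.

The other change behaves the same way, with methyl in place of isopropyl giving a 1.3-fold lower number from compound 2 to compound 4 (0.13 log units; within the scatter) once 2-bromophenyl is present, and this too differs from the earlier step: the same change on two cores in this assay, a 7.4-fold higher number (0.87 log units; beyond the scatter) from compound 1 to compound 3 and a 1.3-fold lower number (0.13 log units; within the scatter) from compound 2 to compound 4, 9.9-fold (1.00 log units) apart, beyond the scatter of two such steps.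

The two changes therefore do not add up in this small set, and each matters here only where the other group is still that of compound 1, which gives 860 nM in this assay, but four compounds in a single cell assay do not show why this happens or whether it holds for other groups.

Going by these compounds, it remains open whether plain phenyl or a chlorophenyl on the sulfonyl sulfur would behave like 3-bromophenyl. On these data alone, it is also open how an ethyl group or a longer chain would compare with isopropyl on the saturated chain carbon.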